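A few compounds are considered here, and "the series" means these few. Any claim that something is new, unique, unknown or untested is made for them only; others in the source may bear on it.

Measured in a physicochemical assay for solubility, read by chemiluminescence, measured as kinetic solubility (a lower number here means a less soluble compound, a higher number a more soluble compound), as follows:
- compound 1 `COc1nn(C)c2cccc(NS(=O)(=O)c3cccc(Cl)c3Cl)c12` gives 80000 nM as a number
- compound 2 `CCn1[nH]c2ncnc(NS(=O)(=O)c3cccc(Cl)c3Cl)c2c1=O` gives >= 383000 nM as a limit of the assay, not a number
- compound 3 `COc1nn(C(C)C)c2ncnc(NS(=O)(=O)c3cccc(Cl)c3Cl)c12` gives 404000 nM as a number

Compound 3 stands higher of the two numbers, and its gap to compound 1 lies beyond the scatter. Compound 4 `COc1nn(CCN(C)C)c2ncnc(NS(=O)(=O)c3cccc(Cl)c3Cl)c12` carries 2-(dimethylamino)ethyl in place of isopropyl on an aromatic nitrogen. Among the compounds with values here, no measured step covers this change. Compound 3 at 404000 nM already reads high, so no step beyond the scatter is expected in this assay in either direction. The estimated step is a 1.1-fold lower number from compound 3 to compound 4 (0.03 log units; within the scatter) and no larger. For compound 4 the estimated value is 380000 nM with an expected range from 220000 nM to 450000 nM as the working figure.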

Compound 4, solubility: 358000 nM
Estimate against measurement, compound 4: 1.1-fold (0.03 log units) above; the range from low to high includes it.
By their numbers in this assay, from the lowest: compound 1; then compounds 4 and 3 (each within the scatter of the next).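

Within the data shown here, on the aromatic nitrogen, the change from isopropyl to 2-(dimethylamino)ethyl gives the first step in this assay that can be read between two compounds: a 1.1-fold lower number from compound 3 to compound 4 (0.05 log units; within the scatter). The two groups therefore read alike at this position, despite the added nitrogen in the chain. The step is read close to a limit of the assay, which is not a number: the limit of >= 383000 nM in this assay, at which 1 of the 4 values shown sits.

Open, going by these compounds, is whether a carboxylic acid, a morpholine-bearing chain or a longer chain on this nitrogen would read any differently. Also open, on these data alone, is whether 2-(dimethylamino)ethyl would give the same result on the core of compound 1, which gives 80000 nM.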